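The source may report more compounds than this note shows. Statements on the series, on what has been measured and on what is new or still open speak of the compounds shown alone.

Three compounds share one core and differ only in the group on the carbonyl carbon at the end of the chain. Compound 1 `CCCCCCC(O)[C@H](CC(C)C)NC(=O)[C@@H](NC(=O)[C@@H](NC(=O)OC(C)(C)C)C(C)C)C(C)C` gives 210 nM in an assay on isolated protein (plant) for inhibition of Pepsin A (Sus scrofa); a higher number here means a weaker inhibitor, a lower number a stronger inhibitor. Compound 2 `CCCCCCC(O)[C@H](CC(C)C)NC(=O)[C@@H](NC(=O)[C@@H](NC(=O)CC(C)(C)C)C(C)C)C(C)C` gives 1100 nM in this assay, and compound 3 `CCCCCCC(O)[C@H](CC(C)C)NC(=O)[C@@H](NC(=O)[C@@H](NC(=O)OC(C)C)C(C)C)C(C)C` gives 1200 nM. Compound 3 therefore carries the highest of the three numbers, though its gap to compound 2 is within the scatter, while compound 1 lies well below it.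

Compound 4 `CCCCCCC(O)[C@H](CC(C)C)NC(=O)[C@@H](NC(=O)[C@@H](NC(=O)C(C)C)C(C)C)C(C)C` differs from compound 3 in one place: isopropyl in place of isopropoxy on a carbonyl carbon. Among the compounds with values here, two measured steps bear on this change. Replacing an alkoxy group by an alkyl group of like size gave a 5.2-fold higher number from compound 1 to compound 2 (0.72 log units; beyond the scatter), whereas swapping one group for another at the same carbonyl carbon gave a 1.1-fold higher number from compound 2 to compound 3 (0.04 log units; within the scatter). The first of these is the closer parallel, so a weaker inhibitor is expected, with a step of about a 2.5-fold higher number from compound 3 to compound 4 (0.40 log units; beyond the scatter). Compound 4 is estimated at 3000 nM, within a range of 1200 nM to 8000 nM.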

Compound 4, half-maximal inhibitory concentration: 3600 nM
Compound 4: middle estimate off by 1.2-fold (0.08 log units), on the low side; low and high end bracket the measured number.
By their numbers in this assay, from the lowest: compound 1; then compounds 2 and 3 (each within the scatter of the next); then compound 4.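

Replacing isopropoxy with isopropyl on this carbonyl carbon gives a 3.0-fold higher number from compound 3 to compound 4 (0.48 log units; beyond the scatter), so a second pair with an oxygen-linked group and a carbon-linked group now points the same way as compound 1 and compound 2. Compound 4 also lies clearly away from the other two compounds, with a 3.3-fold higher number from compound 2 to compound 4 (0.51 log units; beyond the scatter) and a 17-fold higher number from compound 1 to compound 4 (1.23 log units; beyond the scatter), making it the weakest inhibitor of the four and showing how much this one position can matter. The pattern is not a simple rule that oxygen-linked groups do better, however, since compound 2, with neopentyl, and compound 3, with isopropoxy, lie within the scatter of each other.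

Nothing available here explains these differences. As far as these compounds go, it remains open whether a tert-butyl group, a methoxy group or an amine on this carbonyl carbon would fit the same order.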